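The compounds below may be only part of what the source reports. "The series", "measured", "known", "first", "only" and "open" are said of these compounds alone.

Compound 1 `O=C(CCCCC(S)CCS)Nc1ccccc1`: 13.7% in a functional assay on HO8910 cells (Homo sapiens) for inhibition, read by MTT assay, with a stated time of 24 h, tested at 100 ug/mL; on this read-out higher numbers stand for more inhibition of growth at the one concentration tested and lower numbers for less inhibition of growth. Compound 2 `O=C(CCCCC(S)CCS)Nc1ccc(Cl)cc1`: 21.3%. Compound 3 `O=C(CCCCC(CCSC(=O)c1ccccc1)SC(=O)c1ccccc1)Nc1ccccc1`: "not active" (no number reported), with no number given.

From compound 1 to compound 2 the change is chloro in place of hydrogen on an aromatic carbon, and the step of a number 7.6 percentage points higher from compound 1 to compound 2 (within the scatter) is small. Compound 4 `O=C(CCCCC(CCSC(=O)c1ccccc1)SC(=O)c1ccccc1)Nc1ccccc1Cl` carries the same kind of change, (chloro in place of hydrogen on an aromatic carbon), on the core of compound 3; the difference between the two cores is not broken down here. The two places differ: in compound 2 the chloro sits para to a large group, in compound 4 ortho to a large group. Going by the values given here, compound 3 shows no measurable inhibition, and the only comparable step, a number 7.6 percentage points higher from compound 1 to compound 2 (within the scatter), lies within the scatter, so little change is expected. Compound 4 is therefore estimated at 10%, between 0% and 30%.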

Compound 4, percent growth inhibition at one concentration: "not active" (no number reported)
No number was reported for compound 4, so the estimate cannot be set against anything.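

In this assay, compound 3 and compound 4 both lack a number, so no step can be read between them. Going by these compounds, whether phenyl to 2-chlorophenyl changes growth inhibition on this core stays open. No measurement shown here bears on this result.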